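A few compounds are considered here, and "the series" means these few. Any claim that something is new, unique, unknown or untested is made for them only; others in the source may bear on it.

Among the compounds with values here, compound 2, `CC1CC(C(=O)N2CCc3nc(C#Cc4ccccc4)sc3C2)C1`, is the one compound here that gives a number in an assay on HEK293 cells for positive allosteric modulation of metabotropic glutamate receptor 5 (Homo sapiens), read by FLIPR, with a stated time of 1 h; a higher number here means that more compound is needed for the effect, a lower number that less compound is needed: compound 2 gives 81 nM. Compound 1, `C(#Cc1nc2c(s1)CN(C1CCCCC1)CC2)c1ccccc1`, gives only a limit in this assay, > 10000 nM, so its true value is not a number; the limit of > 10000 nM in this assay, at which 1 of the 2 values shown sits, marks that edge. Within the data shown here, the one measured step, an at least 120-fold lower number from compound 1 to compound 2 (2.09 log units; beyond the scatter), shows that replacing cyclohexyl with (3-methylcyclobutyl)carbonyl on the ring amine nitrogen made the compound far more potent.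

Compound 3, `O=C(c1cccc(Cl)c1)N1CCc2nc(C#Cc3ccccc3)sc2C1`, keeps that carbonyl but alters what sits on it: 3-chlorophenyl in place of 3-methylcyclobutyl on a carbonyl carbon. Among the measured compounds shown here, no measured step here compares two different groups on the carbonyl carbon, so the measured step gives no direction for this change; it only shows that an amide at this position is compatible with potency. The step of a 1.2-fold lower number from compound 2 to compound 3 (0.06 log units; within the scatter) is therefore expected to stay within the usual scatter. Compound 3 is estimated at 70 nM, with a range from 15 nM to 350 nM.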

Compound 3, half-maximal effective concentration: 8.7 nM
Compound 3: middle estimate off by 8.0-fold (0.91 log units), on the high side, and the stated range ends above it.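

Compound 1 and compound 2 showed only that a carbonyl on the ring nitrogen is compatible with potency, whereas this change shows that the group on that carbonyl carbon also matters. In this assay, 3-chlorophenyl in place of 3-methylcyclobutyl gives a 9.3-fold lower number from compound 2 to compound 3 (0.97 log units; beyond the scatter), so this group can still move the number well beyond the scatter once the amide is in place. Nothing measured here explains the gain.

The swap changes a four-membered non-aromatic ring to a six-membered aromatic ring and adds a chlorine, so the compounds shown cannot separate the effect of the aromatic ring from that of the chlorine. Also open, on these data alone, is how a plain phenyl, a 3-methylphenyl or a pyridine ring on the carbonyl carbon would compare.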